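Hydroxy to Methoxy on a Pyrazole Amide: Growth Inhibition

The compounds below may be only part of what the source reports. "The series", "measured", "known", "first", "only" and "open" are said of these compounds alone.

Measured so far:
compound 1 `COc1cc(Cl)cc(-c2nn(-c3cccc(NC(=O)c4cccc(C(F)(F)F)c4)c3)cc2-c2ccncc2)c1` — 29.1%
compound 2 `O=C(Nc1cccc(-n2cc(-c3ccncc3)c(-c3cc(O)cc(Cl)c3)n2)c1)c1cc(C(F)(F)F)cc(C(F)(F)F)c1` — 3.15%

Of the compounds shown here, two have been measured in a functional assay on SR cells (Homo sapiens) for inhibition, read by sulforhodamine B assay, with a stated time of 48 h, tested at 10 uM; on this read-out lower numbers stand for a stronger effect and higher numbers for a weaker effect at the one concentration tested. Compound 1 gives 29.1% in this assay, while compound 2 gives 3.15% in this assay; compound 2 therefore stands at the lower, stronger end of the two numbers, a gap beyond the usual scatter. The two differ in more than one place, so no single change can be read from that gap.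

Compound 3 `COc1cc(Cl)cc(-c2nn(-c3cccc(NC(=O)c4cc(C(F)(F)F)cc(C(F)(F)F)c4)c3)cc2-c2ccncc2)c1` keeps the amide part of compound 2 and differs from it only in one spot: methyl in place of hydrogen on an oxygen on an aromatic ring. Going by the values given here, no measured pair shows this change alone. With nothing to go on beyond the structures, a step in this assay of a number 6.9 percentage points higher from compound 2 to compound 3 (within the scatter) is expected, likely small and within or just beyond the scatter, perhaps slightly toward weaker effect. Compound 3 is therefore estimated at 10% in this assay, with a range from 2% to 35%.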

Compound 3, a percentage reported as activity, at one concentration (the size of the read-out at that concentration, not a potency): 41%
Compound 3: middle estimate off by 31 percentage points, on the low side, and the stated range ends below it.
By their numbers in this assay, from the lowest: compound 2; then compound 1; then compound 3.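

In this assay, hydroxy to methoxy on the aromatic ring, with the amide part held fixed, gives a number 37.9 percentage points higher from compound 2 to compound 3 (beyond the scatter), so this oxygen is sensitive to the change: adding a single methyl there costs most of the effect seen with compound 2. With the methoxy held fixed, trifluoromethyl in place of hydrogen on an aromatic carbon of the amide part gives a number 11.9 percentage points higher from compound 1 to compound 3 (beyond the scatter), a smaller move that also goes toward weaker effect. Nothing measured here explains why either step occurs.

The compounds shown leave open how an amine or a longer ethoxy chain at this position would compare with hydroxy and methoxy. They also leave open whether hydroxy to methoxy would bring a step of similar size with only one trifluoromethyl on the amide part.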